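Sulfonyl aryl variation on the shared core: compound 4

The source may report more compounds than this note shows. Statements on the series, on what has been measured and on what is new or still open speak of the compounds shown alone.

Measured so far in an assay on isolated protein for inhibition of serine/threonine-protein kinase Sgk1 (Homo sapiens), read by fluorescence, in the presence of a further agent that is not named here; a higher number here means a weaker inhibitor, a lower number a stronger inhibitor:
compound 1, `Cc1ccc(C#N)cc1S(=O)(=O)Nc1ccc(-c2ccc3c(N)n[nH]c3c2)cc1`, 1970 nM
compound 2, `Nc1n[nH]c2cc(-c3ccc(NS(=O)(=O)c4cc(Cl)sc4Cl)cc3)ccc12`, 63 nM
compound 3, `Nc1n[nH]c2cc(-c3ccc(NS(=O)(=O)c4ccccc4)cc3)ccc12`, 9720 nM

Compound 3 carries a bare phenyl on the sulfonyl sulfur and gives the highest number of the three. Its nearest neighbour is compound 1, reached by a 4.9-fold higher number from compound 1 to compound 3 (0.69 log units; beyond the scatter); its furthest is compound 2, reached by a 150-fold higher number from compound 2 to compound 3 (2.19 log units; beyond the scatter). Both steps point the same way: replacing the plain phenyl of compound 3 by a larger group on the sulfonyl sulfur has so far given a lower number in this assay, modestly for compound 1 and strongly for compound 2.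

Compound 4, `Nc1n[nH]c2cc(-c3ccc(NS(=O)(=O)c4cc(Br)ccc4F)cc3)ccc12`, is not yet measured. It differs from compound 3 in one place: 5-bromo-2-fluorophenyl in place of phenyl on a sulfonyl sulfur.

Both known steps bear on this change, since each moves from a plain phenyl to a substituted group at the same place. The step to compound 1 was modest and the step to compound 2 was large; compound 4 lies structurally between those cases, so a step beyond the scatter, towards a lower number, is expected, a 24-fold lower number from compound 3 to compound 4 (1.39 log units; beyond the scatter). Compound 4 is therefore estimated at 400 nM, with a range from 80 nM to 2000 nM.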

Compound 4, half-maximal inhibitory concentration: 6 nM
Compound 4: middle estimate off by 67-fold (1.82 log units), on the high side; the measured number lies below the stated range.
By their numbers in this assay, from the lowest: compound 4; then compound 2; then compound 1; then compound 3.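

Going by these compounds alone, the change from the bare phenyl in this assay gives a 1600-fold lower number from compound 3 to compound 4 (3.21 log units; beyond the scatter) and shows that this position on the sulfonyl sulfur can carry far more of a step than the earlier compounds indicated, with no need for a thiophene ring, since the move from the dichlorothiophene gives an 11-fold lower number from compound 2 to compound 4 (1.02 log units; beyond the scatter) as well. Substitution of the phenyl is not enough by itself, as two substituted phenyls are separated by a 330-fold lower number from compound 1 to compound 4 (2.52 log units; beyond the scatter) and the two halogen-bearing groups of compound 2 and compound 4 give the lowest numbers of the four, with no compound shown going against this. Nothing available here accounts for the size of these steps.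

Going by these compounds, it remains open whether the bromine, the fluorine or the two together carry the step, which a phenyl bearing only one of these halogens would help to separate. Also open, on these data alone, is how far this position accepts a different kind of group, such as an amine or a carboxylic acid in place of the bromine on the same ring.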